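This account rests on a few compounds, and the source may have more. Where it says the series, first, only, none or still open, it means among the compounds named here.

Measured in a functional assay (aorta) with Oryctolagus cuniculus as the target (on this read-out lower numbers stand for stronger inhibition and higher numbers for weaker inhibition), so far:
compound 1 `Nc1ccnc(-c2nn(Cc3ccccc3F)c3ncccc23)n1`: 270 nM; 265000 nM (2 entries)
compound 2 `CC(C)c1cnc(-c2nn(Cc3ccccc3F)c3ncccc23)nc1N`: 207000 nM
compound 3 `Nc1nc(-c2nn(Cc3ccccc3F)c3ncccc23)ncc1C1CCCCC1`: 561000 nM

Compound 3 stands with the higher of the two single numbers in this assay. Its nearest neighbour is compound 2, reached by a 2.7-fold higher number from compound 2 to compound 3 (0.43 log units; beyond the scatter), a modest step beyond the scatter in which the larger ring group came with the higher number. Among the compounds with values here, compound 1 gives no single number to set beside these two: its entries differ widely, as the several entries of compound 1 in this assay, 270 nM; 265000 nM (2 entries) shows, and no step to compound 3 can be drawn from it.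

Compound 4 `N#Cc1cnc(-c2nn(Cc3ccccc3F)c3ncccc23)nc1N` differs from compound 3 by cyano in place of cyclohexyl on an aromatic carbon. Within the data shown here, the only measured step at this place is the one from compound 2 to compound 3, where a group of more heavy atoms raised the number. Compound 4 carries a group of fewer heavy atoms than either isopropyl or cyclohexyl, so the working expectation in this assay is a move in the opposite direction, of roughly the size already seen, estimated as a 3.1-fold lower number from compound 3 to compound 4 (0.49 log units; beyond the scatter). The spread of compound 1 leaves the range wide. Compound 4 is estimated at 180000 nM, expected between 30000 nM and 800000 nM.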

Compound 4, half-maximal inhibitory concentration: 391000 nM
Estimate against measurement, compound 4: 2.2-fold (0.34 log units) below, and the stated range covers the measured number.
By their numbers in this assay, from the lowest: compounds 2, 4 and 3 (each within the scatter of the next, the first and the last beyond it).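

In this assay this place, ortho to the amino group, now carries three groups, and the step of a 1.4-fold lower number from compound 3 to compound 4 (0.16 log units; within the scatter) and the step of a 1.9-fold higher number from compound 2 to compound 4 (0.28 log units; within the scatter) both leave cyano within the scatter of the two carbon groups. Within the data shown here, the one step beyond the scatter here, from isopropyl to cyclohexyl, therefore does not extend to a simple reading by heavy-atom count: compound 4 goes against such a reading, since its cyano group has fewer heavy atoms than cyclohexyl and yet stays within the scatter of compound 3. The hydrogen-bond acceptor that enters with cyano likewise does not separate compound 4 from compound 2 or compound 3 on this read-out.

What the core gives with no group at this place stays open, as compound 1 offers no single number to compare: the several entries of compound 1 in this assay, 270 nM; 265000 nM (2 entries)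

Also open, as far as these compounds go, is whether a group of another kind at this place, such as a carboxylic acid, an aminomethyl group or a longer chain, would move the number beyond the scatter of compound 4.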